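The source may hold more compounds than are shown below. What is called first, only, known or untested is meant among the compounds shown, and "the series" means these compounds.

Three compounds share one core and are compared in a functional assay on HEK293 cells for agonist activity at G-protein coupled receptor 39 (Homo sapiens), read by scintillation proximity assay and inositol phosphate accumulation, with a stated time of 75 min, in the presence of a further agent that is not named here; a lower number here means that less compound is needed, a higher number that more compound is needed for the effect. Compound 1 `Cc1cc(C)n(CCOC2CC(=O)Nc3c2c(C)nn3-c2ncnc3nc[nH]c23)n1` gives 16 nM in this assay, compound 2 `CCCCCCCCOC1CC(=O)Nc2c1c(C)nn2-c1ncnc2nc[nH]c12` gives 8 nM, and compound 3 `Cc1nn(-c2ncnc3nc[nH]c23)c2c1C(OCc1ccc(C#N)cc1)CC(=O)N2` gives 4 nM. Compound 3 therefore gives the lowest number of the three, its gap to compound 2 lying within the scatter and its gap to compound 1 beyond it, as the steps of a 2.0-fold lower number from compound 2 to compound 3 (0.30 log units; within the scatter) and a 4.0-fold lower number from compound 1 to compound 3 (0.60 log units; beyond the scatter) show.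

Compound 4 `Cc1nn(-c2ncnc3nc[nH]c23)c2c1C(OCCn1nccc1C)CC(=O)N2` is the next member: (5-methyl-1H-pyrazol-1-yl)methyl in place of 4-cyanophenyl on a saturated chain carbon bound to an oxygen on a saturated carbon. Within the data shown here, the step that bears most directly on it is the one from compound 1 to compound 3, where the 4-cyanophenyl replaced a closely related pyrazolylmethyl group and gave a 4.0-fold lower number from compound 1 to compound 3 (0.60 log units; beyond the scatter). Compound 4 returns to a pyrazolylmethyl group, differing from compound 1 only in a methyl on the pyrazole, so the reverse of that step is expected: a modest rise toward the number of compound 1. The expected step is a 3.0-fold higher number from compound 3 to compound 4 (0.48 log units; beyond the scatter). Compound 4 is estimated at 12 nM, within a range from 4 nM to 40 nM.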

Compound 4, half-maximal effective concentration: 10 nM
Compound 4: the middle estimate sits 1.2-fold (0.08 log units) above what was measured, and the stated range covers the measured number.
By their numbers in this assay, from the lowest: compounds 3, 2, 4 and 1 (each within the scatter of the next, the first and the last beyond it).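

In this assay, (5-methyl-1H-pyrazol-1-yl)methyl in place of 4-cyanophenyl gives a step beyond the scatter (a 2.5-fold higher number from compound 3 to compound 4 (0.40 log units; beyond the scatter)), so a second pyrazole side chain now stands apart from the 4-cyanophenyl group. Hydrogen in place of methyl on an aromatic carbon leaves the two pyrazole compounds within the scatter of each other (a 1.6-fold lower number from compound 1 to compound 4 (0.20 log units; within the scatter)), and 5-methyl-1H-pyrazol-1-yl in place of hexyl likewise stays within it (a 1.3-fold higher number from compound 2 to compound 4 (0.10 log units; within the scatter)), so neither the pyrazole methyl nor this swap for the alkyl chain can be read as a real difference. No independent measurement is available to explain these steps.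

The compounds shown leave open how a morpholine or a carboxylic acid would read in place of the pyrazole. They also leave open whether 4-cyanophenyl on a longer chain would keep the number of compound 3 (4 nM).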